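The source may report more compounds than this note shows. Statements on the series, on what has been measured and on what is new or still open speak of the compounds shown alone.

Compound 1 `O=C1/C(=C\c2cccc(Oc3ccccc3)c2)c2ccccc2N1c1c(Cl)cccc1Cl` — in a functional assay on MOLT-4 cells (Homo sapiens) for cytotoxicity, read by MTT assay, with a stated time of 72 h (on this read-out higher numbers stand for an effect only at larger amounts of compound and lower numbers for an effect already at smaller amounts), compound 1 gives 6 ug/mL.
Compound 2 `CN(C)c1ccc(/C=C2\C(=O)N(c3c(Cl)cccc3Cl)c3ccccc32)cc1` — in this assay the entry for compound 2 reads "not determined" (no result reported), so compound 2 has no reported number.

The two measured compounds share one core and differ only in the aromatic group attached to the double-bonded chain carbon. Going by the values given here, compound 1 carries a 3-phenoxyphenyl group there and gives the single value above. Among the compounds with values here, compound 2 carries a 4-(dimethylamino)phenyl group, and for it this assay yields no number at all, so compound 2 stands nowhere on the scale and no step from it can be measured.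

Compound 3 `O=C1/C(=C\c2cccc(Cl)c2)c2ccccc2N1c1c(Cl)cccc1Cl` is the next variation: 3-chlorophenyl in place of 4-(dimethylamino)phenyl on a double-bonded chain carbon bound to a double-bonded ring carbon. Within the data shown here, with no number for compound 2, no measured step is available; the only anchor is compound 1, whose value is 6 ug/mL. Compound 3 is therefore expected to land near compound 1, with no clear direction beyond the scatter, at an estimated 8 ug/mL, plausibly between 2.5 ug/mL and 25 ug/mL.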

Compound 3, concentration for half-maximal effect: 6 ug/mL
Compound 3: middle estimate off by 1.3-fold (0.12 log units), on the high side; low and high end bracket the measured number.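

In this assay, going by these compounds alone, putting chloro in place of phenoxy on an aromatic carbon gives no change at the digits printed from compound 1 to compound 3 (within the scatter), and this is the first measured comparison at this position. On a double-bonded chain carbon bound to a double-bonded ring carbon, the 3-phenoxyphenyl and 3-chlorophenyl groups are therefore not told apart by this read-out, while steps involving compound 2 cannot be read. Nothing measured here offers a reason for this match.

Within the data shown here, with only two numbers, it remains open whether this position tolerates many different groups or these two simply happen to match. A carboxylic acid or a primary amine on that aromatic ring would test this further, since neither group appears among the compounds shown.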